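Swapping a dihydroxyphenyl for a chlorohydroxyphenyl on a hydrazone

A few compounds are considered here, and "the series" means these few. Any claim that something is new, unique, unknown or untested is made for them only; others in the source may bear on it.

Measured so far:
compound 1, `Cc1c(C(=O)N/N=C\c2ccncc2)oc2cccc(O)c12`, >= 40000 nM
compound 2, `Cc1c(C(=O)N/N=C\c2ccc(O)cc2O)oc2cccc(O)c12`, 14800 nM

In a functional assay on PC-3 cells (Homo sapiens) for inhibition (on this read-out higher numbers stand for weaker inhibition and lower numbers for stronger inhibition), compound 2 gives 14800 nM. Compound 1 reaches only a limit of this assay, >= 40000 nM, and this the limit of >= 40000 nM in this assay, at which 1 of the 2 values shown sits, is one of two values shown. Among the measured compounds shown here, compound 2 thus holds the only numerical value; the step of an at least 2.7-fold lower number from compound 1 to compound 2 (0.43 log units; beyond the scatter), which puts 2,4-dihydroxyphenyl in place of pyridin-4-yl, is the single measured step.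

Compound 3, `Cc1c(C(=O)N/N=C\c2cc(Cl)ccc2O)oc2cccc(O)c12`, carries 5-chloro-2-hydroxyphenyl in place of 2,4-dihydroxyphenyl on a carbon with a double bond to nitrogen. No measured step covers this exchange: the only step shown alters a different group at the same position, so it offers no direct guide. The expectation therefore rests on compound 2 alone, with an estimated step of a 1.2-fold lower number from compound 2 to compound 3 (0.09 log units; within the scatter) that stays within the scatter. Compound 3 is expected to give about 12000 nM in this assay, with a range from 4000 nM to 40000 nM.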

Compound 3, half-maximal inhibitory concentration: 3120 nM
Beside the measured number, compound 3's estimate is 3.8-fold (0.59 log units) above it, and the stated range ends above it.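

In this assay the exchange of 2,4-dihydroxyphenyl for 5-chloro-2-hydroxyphenyl gives a 4.7-fold lower number from compound 2 to compound 3 (0.68 log units; beyond the scatter) and so shows that this position still responds when one hydroxyphenyl group replaces another, not only when pyridin-4-yl leaves. Putting 5-chloro-2-hydroxyphenyl in place of pyridin-4-yl gives an at least 12-fold lower number from compound 1 to compound 3 (1.10 log units; beyond the scatter) and widens the range seen at this position on the shared core. From the compounds shown here alone, the true size of that step stays unknown, since compound 1 gives a limit and not a number: the limit of >= 40000 nM in this assay, at which 1 of the 3 values shown sits.

The exchange from compound 2 to compound 3 adds a chlorine and removes a hydroxyl in a single change, so the compounds shown cannot tell which of the two carries the step. A plain 2-hydroxyphenyl group, or a bromine or methoxy group in place of the chlorine, would separate these two changes.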